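Shortening the chain in the cyclic nucleotide series

The source may hold more compounds than are shown below. What is called first, only, known or untested is meant among the compounds shown, and "the series" means these compounds.

The three measured compounds share one core and differ only in the chain that sits on it. Compound 1 `CCCCCCCCc1cn([C@H]2C[C@@H]3OP(=O)(O)OC[C@H]3O2)c(=O)[nH]c1=O` carries octyl; in a functional assay on Raji cells (Homo sapiens) (a higher number here means a weaker inhibitor, a lower number a stronger inhibitor), compound 1 gives 165 ug/mL. Compound 2 `CCCc1cn([C@H]2C[C@@H]3OP(=O)(O)OC[C@H]3O2)c(=O)[nH]c1=O` carries propyl; in this assay compound 2 reaches only the limit of the assay, > 500 ug/mL. Compound 3 `CCCCCc1cn([C@H]2C[C@@H]3OP(=O)(O)OC[C@H]3O2)c(=O)[nH]c1=O` carries pentyl; in this assay compound 3 likewise reaches only the limit, > 500 ug/mL. Compound 3 therefore stands at the limit of > 500 ug/mL in this assay, at which 2 of the 3 values shown sit, together with compound 2, and the step that the two limits leave unreadable from compound 2 to compound 3 cannot be read. The step of an at least 3.0-fold higher number from compound 1 to compound 3 (0.48 log units; beyond the scatter) is the only one near this part of the series that is readable, and it points away from the limit toward a stronger inhibitor only when the chain lengthens.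

Compound 4 `CCCCc1cn([C@H]2C[C@@H]3OP(=O)(O)OC[C@H]3O2)c(=O)[nH]c1=O` is the next shorter chain: hydrogen in place of methyl on a saturated chain carbon, four bonds along the chain from an aromatic carbon. This change cuts the chain between compound 3 and compound 2, both of which sit at the limit, so no readable step bears on it directly. The expectation is that compound 4 again reaches only the limit in this assay, with an estimated value of 600 ug/mL (300 ug/mL to 1500 ug/mL), which means the step that the limit leaves unreadable from compound 3 to compound 4 is expected to show nothing beyond the scatter.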

Compound 4, concentration for 50% inhibition: 82 ug/mL
For compound 4 the middle estimate is 7.3-fold (0.86 log units) above the measured one; the whole stated range lies above it.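

In this assay, removing one methyl from the pentyl chain gives an at least 6.0-fold lower number from compound 3 to compound 4 (0.78 log units; beyond the scatter), and adding one methyl to the propyl chain gives an at least 6.0-fold lower number from compound 2 to compound 4 (0.78 log units; beyond the scatter), so the butyl chain stands apart from both chains that differ from it by a single carbon, and the read-out at this position does not follow chain length steadily. The step of a 2.0-fold lower number from compound 1 to compound 4 (0.30 log units; within the scatter) leaves the butyl and octyl chains indistinguishable, so the longest chain shown is no longer the only one to come off the limit. Compound 2 and compound 3 remain limits, and the step linking them cannot be read: the limit of > 500 ug/mL in this assay, at which 2 of the 4 values shown sit.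

On these data alone, whether a hexyl or heptyl chain behaves like butyl or like pentyl stays open. So does the effect of a decyl chain, or of a carboxylic acid carried on the butyl chain.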